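Cytotoxicity notes on ester-bearing analogues of compound 1

The source may hold more compounds than are shown below. What is called first, only, known or untested is meant among the compounds shown, and "the series" means these compounds.

Compound 1 `Nc1ccc(-c2cc(=O)c3c(N)c(F)cc(F)c3o2)cc1F` is the reference point of the series. In a functional assay on HeLa cells (Homo sapiens) for cytotoxicity, read by neutral red uptake, with a stated time of 3 days (a higher number here means a weaker inhibitor, a lower number a stronger inhibitor), compound 1 gives > 100000 nM, which is a limit of the assay rather than a number. Compound 2 `Nc1ccc(-c2cc(=O)c3c(N)c(F)c(O)c(F)c3o2)cc1F` carries a hydroxy in place of hydrogen on an aromatic carbon; in this assay compound 2 gives > 100000 nM, again a limit. The step that the two limits leave unreadable from compound 1 to compound 2 therefore cannot be read, since the limit of > 100000 nM in this assay, at which 2 of the 3 values shown sit, covers both ends. Compound 3 `CCCCCC(=O)OCc1c(F)c(N)c2c(=O)cc(-c3ccc(N)c(F)c3)oc2c1F` carries a ((pentylcarbonyl)oxy)methyl in place of hydrogen on an aromatic carbon, and in this assay compound 3 gives 34000 nM. For the measured compounds named here, the step of an at least 2.9-fold lower number from compound 1 to compound 3 (0.46 log units; beyond the scatter) is the one readable step, and an at least 2.9-fold lower number from compound 2 to compound 3 (0.46 log units; beyond the scatter) points the same way.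

Compound 4 `CN(C)CC(=O)OCc1c(F)c(N)c2c(=O)cc(-c3ccc(N)c(F)c3)oc2c1F` differs from compound 1 as follows: ((((dimethylamino)methyl)carbonyl)oxy)methyl in place of hydrogen on an aromatic carbon. The change parallels that leading to compound 3, an ester-bearing methyl entering on an aromatic carbon, so a step in the same direction is expected, an at least 2.0-fold lower number from compound 1 to compound 4 (0.30 log units; that floor lies within the scatter), with no measured guide for the dimethylamino variant itself. Compound 4 is estimated at 50000 nM, within 15000 nM to 150000 nM, with a fair chance that the assay again reports only a limit.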

Compound 4, half-maximal inhibitory concentration: 9200 nM
Beside the measured number, compound 4's estimate is 5.4-fold (0.74 log units) above it; measured number outside the range, below it.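

At the aromatic carbon ortho to two fluoro groups, the ester side chain itself now matters in this assay: with the ester-bearing methyl kept, dimethylamino in place of butyl gives a 3.7-fold lower number from compound 3 to compound 4 (0.57 log units; beyond the scatter). Measured against the reference, the ester of compound 4 gives an at least 10-fold lower number from compound 1 to compound 4 (1.03 log units; beyond the scatter), and in place of the hydroxy group it gives an at least 10-fold lower number from compound 2 to compound 4 (1.03 log units; beyond the scatter). Both of these larger steps are floors and not exact sizes, as each starts from a limit: the limit of > 100000 nM in this assay, at which 2 of the 4 values shown sit.

Compound 4 is the only amine-bearing ester shown, so a diethylamino or piperidine-bearing ester of the same chain length, or a longer aminoalkyl chain, would be needed to separate the nitrogen from the shorter chain. A plain hydroxymethyl on the same carbon would show whether the ester link is needed at all.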